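The source may hold more compounds than are shown below. What is called first, only, known or untested is meant among the compounds shown, and "the series" means these compounds.

Measured in a toxicity assay on HepG2 2.2.15 cells (Homo sapiens) for cytotoxicity, read by CellTiter-Glo; a higher number here means that more compound is tolerated, a lower number that less compound is tolerated:
- Compound 1 `CC1(C)CC(=O)N(c2cnn3c2CN(C(=O)Nc2cc(F)c(F)c(F)c2)C(C2CC2)C3)C1`: 115000 nM
- Compound 2 `O=C1NC(c2ccccc2)CN1c1cnn2c1CN(C(=O)Nc1cc(F)c(F)c(F)c1)C(C1CC1)C2`: 38500 nM

Of these two, compound 2 has the lower number, at 38500 nM, so less of it is tolerated. The next compound, compound 3 `O=C1CC(c2cnco2)CN1c1cnn2c1CN(C(=O)Nc1cc(F)c(F)c(F)c1)C(C1CC1)C2`, has not yet been measured. In it, 4-(1,3-oxazol-5-yl)-2-oxopyrrolidin-1-yl stands in place of 2-oxo-4-phenylimidazolidin-1-yl on an aromatic carbon: 4-(1,3-oxazol-5-yl)-2-oxopyrrolidin-1-yl in place of 2-oxo-4-phenylimidazolidin-1-yl on an aromatic carbon.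

For the measured compounds named here, the only measured step bearing on this change is a 3.0-fold lower number from compound 1 to compound 2 (0.48 log units; beyond the scatter). That step runs in the opposite sense in terms of the ring, since compound 3 regains a 2-oxopyrrolidin-1-yl ring like that of compound 1 while still carrying an aromatic ring like compound 2. A partial return upward is therefore expected in this assay, smaller than that measured step. The expected step is a 1.8-fold higher number from compound 2 to compound 3 (0.26 log units; within the scatter). For compound 3 the estimate is 70000 nM, with an expected range from 30000 nM to 150000 nM.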

Compound 3, half-maximal cytotoxic concentration: 139000 nM
Beside the measured number, compound 3's estimate is 2.0-fold (0.30 log units) below it; measured number inside the range.
By their numbers in this assay, from the lowest: compound 2; then compounds 1 and 3 (each within the scatter of the next).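

In this assay the change at this aromatic carbon gives a 3.6-fold higher number from compound 2 to compound 3 (0.56 log units; beyond the scatter) and so shows that an aromatic ring in this substituent does not by itself go with the lower number of compound 2. The other comparison gives a 1.2-fold higher number from compound 1 to compound 3 (0.08 log units; within the scatter) and so shows that 4-(1,3-oxazol-5-yl) and 4,4-dimethyl substitution on the 2-oxopyrrolidin-1-yl ring cannot be told apart in this read-out. No supporting data explain why the numbers fall this way.

The change from compound 2 to compound 3 alters both the non-aromatic ring and the aromatic ring, so the compounds shown do not say which of the two goes with the higher number. A 4-phenyl-2-oxopyrrolidin-1-yl group at the same place would separate these two parts of the change.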